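This account rests on a few compounds, and the source may have more. Where it says the series, first, only, none or still open, it means among the compounds named here.

Measured in a functional assay on A549 cells (Homo sapiens) for antiproliferative activity, read by MTT assay, with a stated time of 48 h; on this read-out lower numbers stand for stronger inhibition and higher numbers for weaker inhibition:
- compound 1 `N#Cc1nc2c(-c3nc4ccccc4[nH]3)c(N)n(CCN3CCCC3)c2nc1C#N`: > 50000 nM
- compound 2 `CCCn1c(N)c(-c2nc3ccccc3[nH]2)c2nc(C#N)c(C#N)nc21`: 1970 nM
- compound 3 `CN(C)CCCn1c(N)c(-c2nc3ccccc3[nH]2)c2nc(C#N)c(C#N)nc21`: 10400 nM

Compound 1 stands at > 50000 nM, which is a limit and not a number. Compound 3 holds the higher of the two actual numbers, and compound 2 is its nearest neighbour.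

Compound 4 `N#Cc1nc2c(-c3nc4ccccc4[nH]3)c(N)n(CCCO)c2nc1C#N` differs from compound 3 as follows: hydroxy in place of dimethylamino on a saturated chain carbon, three bonds along the chain from an aromatic nitrogen. This places hydroxy in place of dimethylamino on a saturated chain carbon, three bonds along the chain from an aromatic nitrogen.

The most direct precedent changes the same place: a 5.3-fold higher number from compound 2 to compound 3 (0.72 log units; beyond the scatter), a modest step. The steps of an at least 25-fold lower number from compound 1 to compound 2 (1.40 log units; beyond the scatter) and an at least 4.8-fold lower number from compound 1 to compound 3 (0.68 log units; beyond the scatter) start from the limit and bear less directly. Hydroxy is not hydrogen, so only part of the first step is expected to reverse in this assay, giving a modest move to a lower number. The expected step is a 2.1-fold lower number from compound 3 to compound 4 (0.32 log units; beyond the scatter). Compound 4 is estimated at 5000 nM, with an expected range of 1500 nM to 20000 nM.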

Compound 4, half-maximal inhibitory concentration: > 50000 nM
Compound 4: only a limit was reported (the forecaster's own chance of this, stated with the estimate: 7%); middle value at least 10-fold (1.00 log units) away from the limit.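

Hydroxy in place of dimethylamino gives an at least 4.8-fold higher number from compound 3 to compound 4 (0.68 log units; beyond the scatter), and hydroxy in place of hydrogen gives an at least 25-fold higher number from compound 2 to compound 4 (1.40 log units; beyond the scatter). At this chain carbon, then, a replacement for hydrogen can cost more than the dimethylamino of compound 3 did, and the dimethylamino result does not carry over to hydroxy. The result for compound 4 is a limit and not a number, and the step from compound 1 to compound 4 cannot be read: the limit of > 50000 nM in this assay, at which 2 of the 4 values shown sit.

Going by these compounds, how far compound 4 lies past that limit stays open. Also open, on these data alone, is whether a primary amine, a carboxylic acid or a longer alkyl chain at this position would give a measurable number.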